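The compounds below may be only part of what the source reports. "The series", "measured", "known", "first", "only" and "open" are said of these compounds alone.

In a functional assay on HepG2 cells (Homo sapiens) for antiproliferative activity, read by MTT assay, with a stated time of 48 h (a lower number here means a stronger inhibitor, a higher number a weaker inhibitor), compound 1 `COc1ccc(-c2ccc3c(c2)C(=O)C(=O)N3c2ccc(OC)cc2)cc1` gives > 10000 nM, and this is a limit of the assay, not a number. Compound 2 `COc1ccc(-c2ccc3c(c2)C(=O)C(=O)N3Cc2cccc(Cl)c2)cc1`, which carries 3-chlorobenzyl on the amide-type nitrogen in a ring, gives 320 nM. Compound 3 `COc1ccc(-c2ccc3c(c2)C(=O)C(=O)N3Cc2ccc(C)cc2)cc1`, which carries 4-methylbenzyl at that place, gives 330 nM. The two numbers stand level, with a 1.0-fold higher number from compound 2 to compound 3 (0.01 log units; within the scatter).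

Compound 4 `COc1ccc(-c2ccc3c(c2)C(=O)C(=O)N3Cc2ccccc2OC)cc1` has not yet been measured. It differs from compound 3 by 2-methoxyphenyl in place of 4-methylphenyl on a saturated chain carbon bound to an amide-type nitrogen in a ring, so 2-methoxybenzyl takes the place of 4-methylbenzyl.

The closest measured precedent is the change between compound 2 and compound 3, which also swaps one substituted benzyl group for another and gives a 1.0-fold higher number from compound 2 to compound 3 (0.01 log units; within the scatter). The two large steps, an at least 31-fold lower number from compound 1 to compound 2 (1.49 log units; beyond the scatter) and an at least 30-fold lower number from compound 1 to compound 3 (1.48 log units; beyond the scatter), are of a different kind. Each replaces 4-methoxyphenyl with a benzyl group, whereas compound 4 keeps a benzyl group. Within the data shown here, only two benzyl compounds have been measured, however, and neither carries 2-methoxyphenyl, so the precedent is thin and the range must stay wide.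

No step beyond the scatter is expected, and the estimated change is a 1.2-fold higher number from compound 3 to compound 4 (0.08 log units; within the scatter). For compound 4 the expected value is 400 nM, with an estimated range from 120 nM to 1500 nM.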

Compound 4, half-maximal inhibitory concentration: 130 nM
Compound 4: the middle estimate sits 3.1-fold (0.49 log units) above what was measured; the range from low to high includes it.
By their numbers in this assay, from the lowest: compound 4; then compounds 2 and 3 (each within the scatter of the next). At a limit, above all of these: compound 1.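

Compounds 2 and 3 stood level, so the two benzyl groups measured so far gave no sign that a change on this ring could move the number. Compound 4 gives that first sign in this assay, with a 2.5-fold lower number from compound 3 to compound 4 (0.40 log units; beyond the scatter) and a 2.5-fold lower number from compound 2 to compound 4 (0.39 log units; beyond the scatter), both modest but beyond the scatter, so 2-methoxybenzyl separates from 4-methylbenzyl and from 3-chlorobenzyl on the amide-type nitrogen in a ring. The large step, an at least 76-fold lower number from compound 1 to compound 4 (1.88 log units; beyond the scatter), starts from a limit of the assay held by compound 1, not from a number: the limit of > 10000 nM in this assay, at which 1 of the 4 values shown sits.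

Compound 4 alone carries a methoxy group on the benzyl ring, so the compounds shown cannot tell whether the gain follows that group itself or its place on the ring, a question that 4-methoxybenzyl and 2-methylbenzyl would help to settle. Also open, from the compounds shown here alone, is how far this position tolerates other kinds of group, such as an amine on the benzyl ring, a carboxylic acid there, or a longer chain in the form of 2-phenylethyl.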